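Methyl to ethyl on the chain: compound 4

The source may hold more compounds than are shown below. What is called first, only, known or untested is meant among the compounds shown, and "the series" means these compounds.

Compound 1 `Nc1cc(OCCNc2ccnc3cc(Cl)ccc23)nc(N)n1` gives 0.9
Compound 2 `CC(COc1cc(N)nc(N)n1)Nc1ccnc2cc(Cl)ccc12` gives 0.92
Compound 3 `Nc1cc(OCCCNc2ccnc3cc(Cl)ccc23)nc(N)n1` gives 1.01

These three values come from a physicochemical assay for lipophilicity, read by HPLC, in phosphate buffer, measured as octanol-water partition, at pH 7.4 (on this read-out lower numbers stand for lower lipophilicity and higher numbers for higher lipophilicity), and lie within the usual scatter of one another, so compound 2 (0.92) holds no separate place among them.

Compound 4 `CCC(COc1cc(N)nc(N)n1)Nc1ccnc2cc(Cl)ccc12` follows from compound 2 through one change (methyl in place of hydrogen on a saturated chain carbon, two bonds along the chain from a nitrogen on an aromatic ring), a methyl in place of hydrogen on a saturated chain carbon, two bonds along the chain from a nitrogen on an aromatic ring. The same difference reads methyl to ethyl.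

Within the data shown here, one measured step bears on it, also a methyl in place of hydrogen on a saturated chain carbon, though at a different place on the chain (a number 0.02 log units higher from compound 1 to compound 2 (within the scatter)). That step is small, so no shift beyond the scatter is expected in this assay for compound 4, at most a slight rise.

The expected change is small (a number 0.08 log units higher from compound 2 to compound 4 (within the scatter)).

The estimated value for compound 4 is 1 within an expected range (0.75 to 1.3).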

Compound 4, distribution coefficient: 2.47
For compound 4 the middle estimate is 1.47 log units below the measured one; measured number above the stated range.
By their numbers in this assay, from the lowest: compounds 1, 2 and 3 (each within the scatter of the next); then compound 4.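

In this assay, hydrogen and methyl on this chain carbon stay within the scatter of each other, with a number 0.02 log units higher from compound 1 to compound 2 (within the scatter). Ethyl on the same carbon behaves differently, with a number 1.57 log units higher from compound 1 to compound 4 (beyond the scatter), so the read-out at this position does not rise evenly with each added carbon across these three compounds. Extending methyl to ethyl, a methyl in place of hydrogen on a saturated chain carbon, two bonds along the chain from a nitrogen on an aromatic ring, accounts for nearly all of that rise, with a number 1.55 log units higher from compound 2 to compound 4 (beyond the scatter).

As far as these compounds go, whether a propyl group or a longer chain on this carbon keeps the number as high as in compound 4, and how an amine or a carboxylic acid there would read, remains open. The data shown offer no measured explanation for the size of this step.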